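Coumarin thioester series: migration assay, halogen swap

The source may hold more compounds than are shown below. What is called first, only, known or untested is meant among the compounds shown, and "the series" means these compounds.

Measured compounds:
compound 1 `CC(=O)OCc1ccc2oc(=O)c(C(=O)Oc3cccc(Cl)c3)cc2c1` – 95.2%
compound 2 `CC(=O)OCc1ccc2oc(=O)c(C(=O)Sc3cccc(Cl)c3)cc2c1` – 76.5%

Among the measured compounds shown here, in a functional assay on HT-1080 cells (Homo sapiens), read by transwell migration, with a stated time of 24 h, tested at 0.1 uM (on this read-out higher numbers stand for a weaker effect at the one concentration tested and lower numbers for a stronger effect), compound 1 gives 95.2%, the higher of the two numbers measured so far; its nearest neighbour is compound 2, which in this assay gives 76.5%. For the measured compounds named here, the one step recorded, a number 18.7 percentage points lower from compound 1 to compound 2 (beyond the scatter), is a modest one beyond the scatter and is the only guide available.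

Compound 3 `CC(=O)OCc1ccc2oc(=O)c(C(=O)Sc3cccc(Br)c3)cc2c1` is not yet measured. It differs from compound 1 in one place: (3-bromophenyl)sulfanyl in place of 3-chlorophenoxy on a carbonyl carbon. Part of this change, the sulfur for oxygen on the carbonyl carbon, is the same move seen from compound 1 to compound 2, and that step, a number 18.7 percentage points lower from compound 1 to compound 2 (beyond the scatter), bears directly on it. Going by the values given here, the other part, bromine for chlorine on the ring, has no measured counterpart here, so nothing can be said of it beyond the two values shown.

The expectation is therefore a step in this assay of roughly the size of the measured one, in the lowering direction, a number 19.2 percentage points lower from compound 1 to compound 3 (beyond the scatter). Compound 3 is estimated at 76%, with a range from 60% to 92%.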

Compound 3, a percentage reported as activity, at one concentration (the size of the read-out at that concentration, not a potency): 79.6%
The estimate for compound 3 lay 3.6 percentage points below the measured number; the measured number falls inside the stated range.
By their numbers in this assay, from the lowest: compounds 2 and 3 (each within the scatter of the next); then compound 1.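

In this assay, bromo in place of chloro on an aromatic carbon gives a number 3.1 percentage points higher from compound 2 to compound 3 (within the scatter), so the halogen swap makes no readable difference between these two thioesters. Replacing 3-chlorophenoxy with (3-bromophenyl)sulfanyl gives a number 15.6 percentage points lower from compound 1 to compound 3 (beyond the scatter), in the same direction as the step with chlorine retained, a number 18.7 percentage points lower from compound 1 to compound 2 (beyond the scatter), so across these three compounds the lower number goes with sulfur on the carbonyl carbon whichever of the two halogens is present, and no compound shown goes against this. No measured data bear on why the sulfur compounds read lower or why the halogen swap leaves the number within the scatter.

Still open, going by these compounds, is whether an amide nitrogen on the carbonyl carbon, in place of the sulfur or oxygen, would read with compound 1 or with compound 2, and whether a fluoro or methoxy group on the same aromatic carbon would stay within the scatter of chloro and bromo. With a single concentration behind each number, these values give the size of the read-out at that concentration and leave potency open.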